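The source may hold more compounds than are shown below. What is called first, only, known or untested is meant among the compounds shown, and "the series" means these compounds.

Compound 1, `O=C(Nc1ccc(Cl)cc1CN1C(=O)c2ccccc2C1=O)c1cccnc1`, in an assay on CHO cells for positive allosteric modulation of metabotropic glutamate receptor 5 (Rattus norvegicus), read by FLIPR (a lower number here means that less compound is needed, a higher number that more compound is needed for the effect), gives < 1000 nM, which is a limit of this assay and not a number.
Compound 2, `O=C(Nc1ccc(Cl)cc1CN1C(=O)c2ccccc2C1=O)c1ccccc1C(F)(F)F`, in this assay gives < 1000 nM, again a limit rather than a number.

Within the data shown here, compound 2 therefore stands at the limit of this assay, and the only other measured compound stands there with it (the limit of < 1000 nM in this assay, at which 2 of the 2 values shown sit). Among the measured compounds shown here, the single step between them, a step that the two limits leave unreadable from compound 1 to compound 2, is one that the two limits leave unreadable, so its size and direction are not known.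

Compound 3, `O=C(Nc1ccc(Cl)cc1CN1C(=O)c2ccccc2C1=O)c1ncccn1`, differs from compound 2 by pyrimidin-2-yl in place of 2-(trifluoromethyl)phenyl on a carbonyl carbon. For the measured compounds named here, the one measured step bears on this change only in kind, since it also exchanges the aromatic group on the carbonyl carbon, and it gives no size to lean on. No step beyond the scatter can be expected in either direction from what is shown, and the estimate for compound 3 is anchored to where compound 2 stands. The step from compound 2 to compound 3 is estimated as a step that the limit leaves unreadable from compound 2 to compound 3. Compound 3 is estimated at 500 nM, with a range from 100 nM to 2500 nM.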

Compound 3, half-maximal effective concentration: < 1000 nM
Compound 3 ended at the assay's limit; the forecaster's own chance of this, stated with the estimate: 60%; the middle value is on the limit's open side.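

Compound 3 sits with compound 1 and compound 2 at the limit of this assay, so no step among these three compounds can be read: the limit of < 1000 nM in this assay, at which 3 of the 3 values shown sit.

What the compounds shown leave open is how far each lies beyond that limit, and so whether pyridin-3-yl, 2-(trifluoromethyl)phenyl and pyrimidin-2-yl on the carbonyl carbon differ at all.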